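The compounds below may be only part of what the source reports. "The series", "measured", "known", "first", "only" and "open" are said of these compounds alone.

Measured so far:

Compound 1, `CC1=CC[C@H](C(C)(C)NC(=S)N/N=C/c2ccccc2)CC1`, in a functional assay on UACC-62 cells (Homo sapiens) for inhibition, read by sulforhodamine B assay, with a stated time of 48 h (on this read-out lower numbers stand for stronger inhibition of growth and higher numbers for weaker inhibition of growth), compound 1 gives 31600 nM.
Compound 2, `COc1ccc(/C=N/NC(=S)NC(C)(C)[C@H]2CC=C(C)CC2)cc1`, in this assay compound 2 gives 13300 nM.
Compound 3, `CC1=CC[C@H](C(C)(C)NC(=S)N/N=C(\C)c2ccccc2)CC1`, in this assay compound 3 reaches only a limit of the assay, > 100000 nM.

Compound 1 and compound 2 differ in one place: methoxy in place of hydrogen on an aromatic carbon. This change brought a 2.4-fold lower number from compound 1 to compound 2 (0.38 log units; beyond the scatter). Compound 3 sits at the upper limit of this assay, the point described by the limit of > 100000 nM in this assay, at which 1 of the 3 values shown sits, so its value is not a number and the difference between the core of compound 1 and the core of compound 3 is not broken down here.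

Compound 4, `COc1ccc(/C(C)=N/NC(=S)NC(C)(C)[C@H]2CC=C(C)CC2)cc1`, has not yet been measured in this assay. It differs from compound 3 in one place: methoxy in place of hydrogen on an aromatic carbon. The place of the change is the same as between compound 1 and compound 2, so it is the same change, made on the core of compound 3 rather than that of compound 1.

The step from compound 3 to compound 4 is expected to resemble the step seen from compound 1 to compound 2, a 2.4-fold lower number from compound 1 to compound 2 (0.38 log units; beyond the scatter), but it starts from a limit, so the result may again be only a limit. Compound 4 is expected to show a number no higher from compound 3 to compound 4 (the limit leaves the size open) in this assay. Compound 4 is estimated at 100000 nM, within 40000 nM to 300000 nM.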

Compound 4, concentration for 50% growth inhibition: 95300 nM
Estimate against measurement, compound 4: 1.0-fold (0.02 log units) above, and the stated range covers the measured number.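

In this assay, the change from hydrogen to methoxy on the core of compound 3 gives an at least 1.0-fold lower number from compound 3 to compound 4 (0.02 log units; that floor lies within the scatter). Compound 3 stands only at a limit of the assay, > 100000 nM, which makes this step a floor and not a measured size. The result is compatible with the lower number seen on the core of compound 1, but it does not show that the change carries over to the second core with the same size, or with any size beyond the scatter, and the two steps can only be set side by side: the same change on two cores in this assay, a 2.4-fold lower number (0.38 log units; beyond the scatter) from compound 1 to compound 2 and an at least 1.0-fold lower number (0.02 log units; that floor lies within the scatter) from compound 3 to compound 4; the limit leaves it open whether they differ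

Among the compounds shown, this place on the aromatic ring carries only hydrogen or methoxy, which leaves open whether a fluorine, a hydroxyl or a dimethylamino group there would follow the same course on either core. As far as these compounds go, it also remains open how an ethyl group would read in place of the methyl that sets the core of compound 3 apart from the core of compound 1, and whether the change from phenyl to 4-methoxyphenyl would give a readable step on such a core.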